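Shrinking the Amide Substituent to Cyclopropyl

This account rests on a few compounds, and the source may have more. Where it says the series, first, only, none or still open, it means among the compounds named here.

Two compounds share one core and differ only in the group on an amide-type nitrogen. Compound 1 `O=C(COc1ccc2cc(C(O)(C(F)(F)F)C(F)(F)F)c(O)cc2c1)NCc1ccc(F)cc1` carries a 4-fluorobenzyl there. In an assay on isolated protein for inhibition of tyrosine-protein phosphatase non-receptor type 13 (Homo sapiens), read by spectrophotometry (on this read-out higher numbers stand for weaker inhibition and lower numbers for stronger inhibition), compound 1 gives > 20000 nM, which is a limit of the assay rather than a number. Compound 2 `O=C(COc1ccc2cc(C(O)(C(F)(F)F)C(F)(F)F)c(O)cc2c1)Nc1ccc(-c2ccccc2)cc1` carries a 4-phenylphenyl at the same place, and in this assay compound 2 gives 2800 nM. That is the only number shown, since the other value is a limit. The step of an at least 7.1-fold lower number from compound 1 to compound 2 (0.85 log units; beyond the scatter) shows that the larger aromatic group went together with stronger inhibition.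

Compound 3 `O=C(COc1ccc2cc(C(O)(C(F)(F)F)C(F)(F)F)c(O)cc2c1)NC1CC1` is not yet measured. The change cyclopropyl in place of 4-phenylphenyl on an amide-type nitrogen swaps a large group for a small one. For the measured compounds named here, the only measured step, an at least 7.1-fold lower number from compound 1 to compound 2 (0.85 log units; beyond the scatter), moved from a smaller group to 4-phenylphenyl and lowered the number; moving from 4-phenylphenyl to the smaller cyclopropyl is expected to run the other way, raising the number beyond the scatter, estimated as a 7.1-fold higher number from compound 2 to compound 3 (0.85 log units; beyond the scatter). Compound 3 is therefore expected to give about 20000 nM in this assay, within a range from 6000 nM to 60000 nM, with a fair chance that only a limit is reported.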

Compound 3, half-maximal inhibitory concentration: > 20000 nM
Compound 3: no number, only a limit; the forecaster's own chance of this, stated with the estimate: 55%; the middle value sits exactly at the limit.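

Going from 4-phenylphenyl to cyclopropyl on the amide-type nitrogen weakens inhibition in this assay, with an at least 7.1-fold higher number from compound 2 to compound 3 (0.85 log units; beyond the scatter). This shows that a small ring of carbon does not preserve the activity of compound 2 at this place, and that 4-fluorobenzyl is not alone in failing to give a readable number. Compound 1 and compound 3 each stand at a limit, so the step between them cannot be read, and these two groups cannot be ranked against each other; of the three groups shown, only 4-phenylphenyl gives a number, while the weak end of the scale stays unresolved: the limit of > 20000 nM in this assay, at which 2 of the 3 values shown sit.

Going by these compounds, it remains open whether a single phenyl joined directly to the nitrogen would be enough, or whether both aromatic rings of 4-phenylphenyl are needed. Also open, on these data alone, is how a carboxylic acid or an amine carried on the 4-phenylphenyl group would read, and whether either would improve on compound 2, at 2800 nM.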